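Trading a trifluoromethyl for two chlorines on a urea

The compounds below may be only part of what the source reports. "The series", "measured", "known", "first", "only" and "open" are said of these compounds alone.

Of the compounds shown here, three of a shared core have been tested in a functional assay on HCT-116 cells (Homo sapiens) for inhibition, read by sulforhodamine B assay, with a stated time of 48 h; on this read-out higher numbers stand for weaker inhibition of growth and lower numbers for stronger inhibition of growth. Compound 1 `O=C(Nc1cccc(-n2cc(-c3ccncc3)c(-c3ccc(Cl)c(O)c3)n2)c1)Nc1cccc(C(F)(F)F)c1` gives 1390 nM. Compound 2 `COc1cc(-c2nn(-c3cccc(NC(=O)Nc4cc(C(F)(F)F)cc(C(F)(F)F)c4)c3)cc2-c2ccncc2)ccc1Cl` gives 643 nM, and compound 3 `COc1cc(-c2nn(-c3cccc(NC(=O)c4cccc(C(F)(F)F)c4)c3)cc2-c2ccncc2)ccc1Cl` gives 1670 nM. Among these three numbers compound 1 stands second highest: its value and that of compound 3 lie within the scatter of each other, so nothing can be said about which of the two inhibits growth more strongly, while compound 2 gives a number that is lower than that of compound 1 by a margin beyond the scatter.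

Compound 4 `O=C(Nc1cccc(-n2cc(-c3ccncc3)c(-c3ccc(Cl)c(O)c3)n2)c1)Nc1ccc(Cl)c(Cl)c1` differs from compound 1 in one place: 3,4-dichlorophenyl in place of 3-(trifluoromethyl)phenyl on an amide-type nitrogen. Among the compounds with values here, no pair of measured compounds differs in just one place, so there is no measured step to lean on for the size of this change. The three measured values span only a narrow band, and the change keeps the urea and the rest of the molecule intact, so the step from compound 1 to compound 4 is expected to be small, most likely not beyond the scatter, with a slight lean toward a lower number: a 1.4-fold lower number from compound 1 to compound 4 (0.14 log units; within the scatter). On that basis compound 4 is estimated to give 1000 nM, expected to fall between 400 nM and 2500 nM.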

Compound 4, concentration for 50% growth inhibition: 1190 nM
For compound 4 the middle estimate is 1.2-fold (0.08 log units) below the measured one; low and high end bracket the measured number.
By their numbers in this assay, from the lowest: compounds 2, 4, 1 and 3 (each within the scatter of the next, the first and the last beyond it).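

In this assay, within the data shown here, the exchange of 3-(trifluoromethyl)phenyl for 3,4-dichlorophenyl gives a 1.2-fold lower number from compound 1 to compound 4 (0.07 log units; within the scatter), the first comparison here in which only one part of the molecule differs. The two compounds cannot be told apart in this read-out, so at this place on the urea, one substituted phenyl ring can stand in for the other with no measurable consequence, even though the groups differ in their substituents and the leaving group has 10 heavy atoms against 8 for the entering one. No supporting measurement is available to explain this result.

From the compounds shown here alone, two substituted phenyl rings are a narrow sample, so it remains open whether this position would accept something quite different on the same nitrogen, such as an unsubstituted phenyl ring, a carboxylic acid or a longer alkyl chain. Going by these compounds, it is also open whether the two groups would still match if the rest of the molecule were changed, for example with a methoxy group in place of the hydroxyl group on the chlorinated ring of compound 1.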